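Tetrahydropyranyl replaces methoxypyridyl on a substance-P receptor ligand series

This account rests on a few compounds, and the source may have more. Where it says the series, first, only, none or still open, it means among the compounds named here.

Compound 1, `C[C@@H](O[C@H]1CN2C(=O)C=C(c3ccccc3)CC2[C@@H]1c1ccc(F)cc1)c1cc(C(F)(F)F)cc(C(F)(F)F)c1`: 89.5 nM
Compound 2, `C[C@@H](O[C@H]1CN2C(=O)C=C(c3ccc(F)cc3)CC2[C@@H]1c1ccc(F)cc1)c1cc(C(F)(F)F)cc(C(F)(F)F)c1`: 100 nM
Compound 3, `COc1cc(C2=CC(=O)N3C[C@H](O[C@H](C)c4cc(C(F)(F)F)cc(C(F)(F)F)c4)[C@@H](c4ccc(F)cc4)C3C2)ccn1`: 44 nM

In an assay on CHO cells for displacement of a labelled ligand from Substance-P receptor (Homo sapiens), in the presence of a further agent that is not named here (a lower number here means a stronger inhibitor, a higher number a weaker inhibitor), compound 3 gives the lowest number of the three, with a 2.0-fold lower number from compound 1 to compound 3 (0.31 log units; beyond the scatter) and a 2.3-fold lower number from compound 2 to compound 3 (0.36 log units; beyond the scatter) both modest but beyond the scatter, while a 1.1-fold higher number from compound 1 to compound 2 (0.05 log units; within the scatter) lies within it. Compound 4, `C[C@@H](O[C@H]1CN2C(=O)C=C(C3CCOCC3)CC2[C@@H]1c1ccc(F)cc1)c1cc(C(F)(F)F)cc(C(F)(F)F)c1`, carries oxan-4-yl in place of 2-methoxypyridin-4-yl on a double-bonded ring carbon. For the measured compounds named here, the two steps that change the group at this position, from compound 1 and from compound 2 to compound 3, each moved the number only modestly, yet neither exchanged an aromatic ring for a saturated one, so no measured step covers this change directly. The account therefore expects a loss of potency, with a 3.0-fold higher number from compound 3 to compound 4 (0.47 log units; beyond the scatter), and estimates compound 4 at 130 nM in this assay, within 40 nM to 450 nM.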

Compound 4, half-maximal inhibitory concentration: 3.2 nM
Estimate against measurement, compound 4: 41-fold (1.61 log units) above; the measured number lies below the stated range.
By their numbers in this assay, from the lowest: compound 4; then compound 3; then compounds 1 and 2 (each within the scatter of the next).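

For the compounds shown here, at the double-bonded ring carbon, oxan-4-yl gives the only large steps in this assay: a 14-fold lower number from compound 3 to compound 4 (1.14 log units; beyond the scatter), a 31-fold lower number from compound 2 to compound 4 (1.49 log units; beyond the scatter) and a 28-fold lower number from compound 1 to compound 4 (1.45 log units; beyond the scatter). Exchanges among phenyl, 4-fluorophenyl and 2-methoxypyridin-4-yl had moved the number only modestly or within the scatter, so across these four compounds, the one non-aromatic ring separates far more strongly than any difference among the aromatic rings. No measurement given here explains the gain. The compounds shown leave open whether the gain requires the ring oxygen of oxan-4-yl, which a cyclohexyl ring would test, and whether a piperidin-4-yl ring, which carries an amine, would keep it.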